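This account rests on a few compounds, and the source may have more. Where it says the series, first, only, none or still open, it means among the compounds named here.

Measured in an ADME assay on THP-1 cells (Homo sapiens) for cytotoxicity, read by flow cytometry and propidium iodide staining, with a stated time of 72 h; on this read-out lower numbers stand for stronger inhibition and higher numbers for weaker inhibition:
compound 1 `Nc1ccc2oc(-c3ccc(F)cc3)cc(=O)c2c1`: 10000 nM
compound 2 `Nc1ccc2oc(-c3ccc(F)cc3)c(O)c(=O)c2c1`: 4000 nM
compound 3 `COc1c(-c2ccccc2F)oc2ccc(N)cc2c1=O`: > 125000 nM (a limit, not a number)

Compound 3 stands at the limit of > 125000 nM in this assay, at which 1 of the 3 values shown sits, a limit and not a number, so any step from it has no exact size. Compound 4 `COc1c(-c2ccc(F)cc2)oc2ccc(N)cc2c1=O` differs from compound 3 by 4-fluorophenyl in place of 2-fluorophenyl on an aromatic carbon. Among the compounds with values here, no measured step covers this exchange. Within the data shown here, the only measured step is a 2.5-fold lower number from compound 1 to compound 2 (0.40 log units; beyond the scatter), a modest one for hydroxy in place of hydrogen on an aromatic carbon, and it bears only indirectly. More relevant is that 4-fluorophenyl is carried by compound 1 at 10000 nM and by compound 2 at 4000 nM. A lower number than the limit of compound 3 is therefore expected in this assay, although a second limit result remains possible. The expected shift is an at least 3.1-fold lower number from compound 3 to compound 4 (0.49 log units; beyond the scatter), an estimate resting on very few compounds. For compound 4 the estimated value is 40000 nM, with an expected range of 8000 nM to 125000 nM.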

Compound 4, half-maximal inhibitory concentration: 36000 nM
The estimate for compound 4 lay 1.1-fold (0.05 log units) above the measured number, and the stated range covers the measured number.
By their numbers in this assay, from the lowest: compound 2; then compound 1; then compound 4. At a limit, above all of these: compound 3.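

Compound 3 remains a limit and not a number: the limit of > 125000 nM in this assay, at which 1 of the 4 values shown sits.

In this assay, on these data alone, 4-fluorophenyl in place of 2-fluorophenyl, on the aromatic carbon next to the ring oxygen, gives an at least 3.4-fold lower number from compound 3 to compound 4 (0.54 log units; beyond the scatter), so where the fluorine sits on the phenyl ring matters in this methoxy series, though the full size of the step is unknown. With 4-fluorophenyl kept, methyl in place of hydrogen on the oxygen gives a 9.0-fold higher number from compound 2 to compound 4 (0.95 log units; beyond the scatter), and methoxy in place of hydrogen on the aromatic carbon gives a 3.6-fold higher number from compound 1 to compound 4 (0.56 log units; beyond the scatter), leaving the methoxy compound with the highest measured number of the three 4-fluorophenyl compounds.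

Open, as far as these compounds go, is whether 2-fluorophenyl has the same effect with hydroxy or hydrogen in place of methoxy, as only compound 3 carries that group. Also open, from the compounds shown here alone, is how an unsubstituted phenyl, or an ethoxy group in place of methoxy, would fall.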